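Chloro to Dimethylamino: Following Compound 2 to Compound 4

The compounds below may be only part of what the source reports. "The series", "measured", "known", "first", "only" and "open" are said of these compounds alone.

Of the compounds shown here, three that share one core have been measured. Compound 1 `Cc1ccc(S(=O)(=O)NC(=O)/C=C/c2ccc(Cl)cc2)cc1` carries a methyl on an aromatic carbon; in a functional assay on B16-F10 cells (Mus musculus) for antiproliferative activity, read by ELISA and MTT assay, with a stated time of 48 h (on this read-out higher numbers stand for weaker inhibition and lower numbers for stronger inhibition), compound 1 gives 4.6 ug/mL. Compound 2 `O=C(/C=C/c1ccc(Cl)cc1)NS(=O)(=O)c1ccc(Cl)cc1` carries a chloro in place of that methyl, and in this assay compound 2 gives 2.5 ug/mL. Compound 3 `O=C(/C=C/c1ccc(Cl)cc1)NS(=O)(=O)c1ccc(Br)cc1` carries a bromo instead, and in this assay compound 3 gives 2.8 ug/mL. Compound 2 has the lowest of the three numbers, yet the steps that set it apart, a 1.8-fold lower number from compound 1 to compound 2 (0.26 log units; within the scatter) and a 1.1-fold higher number from compound 2 to compound 3 (0.05 log units; within the scatter), both fall within the scatter, as does a 1.6-fold lower number from compound 1 to compound 3 (0.22 log units; within the scatter); nothing here lets compound 2 be called the strongest.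

Compound 4 `CN(C)c1ccc(/C=C/C(=O)NS(=O)(=O)c2ccc(Cl)cc2)cc1` is not yet measured. It differs from compound 2 in one place: dimethylamino in place of chloro on an aromatic carbon. All three measured steps exchange one small group on that same aromatic carbon, and none of them moved the number beyond the scatter. None involves dimethylamino, so they offer only indirect guidance: this position has so far tolerated exchange without a large shift. On that basis, compound 4 is expected to show a step of a 1.4-fold higher number from compound 2 to compound 4 (0.15 log units; within the scatter), which is no change beyond the scatter. The estimate for compound 4 in this assay is 3.5 ug/mL, with a range from 1.2 ug/mL to 10 ug/mL.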

Compound 4, half-maximal inhibitory concentration: 2.8 ug/mL
Estimate against measurement, compound 4: 1.3-fold (0.10 log units) above, within the range that was stated.
By their numbers in this assay, from the lowest: compounds 2, 3, 4 and 1 (each within the scatter of the next).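

In this assay, the exchange gives a 1.1-fold higher number from compound 2 to compound 4 (0.05 log units; within the scatter), so replacing chloro, a single heavy atom, with dimethylamino, which has three heavy atoms and one hydrogen-bond acceptor, causes no shift beyond the scatter. This exchange also reaches a new place: it replaces the chloro that compounds 1, 2 and 3 all keep, whereas their steps exchanged a group on the other aromatic ring, so small exchanges on either ring have now stayed within the scatter in this series. Nothing available explains why the larger group leaves the number within the scatter, and the data offer no measurement that bears on it.

Dimethylamino is the only replacement for this chloro among the compounds shown, so it remains open whether a carboxylic acid or a longer alkyl chain on this aromatic carbon would also stay within the scatter. As far as these compounds go, it is also open whether dimethylamino here, paired with the methyl of compound 1 or the bromo of compound 3 on the other ring, would give a number within the scatter of compound 4.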